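Methylating the hydroxymethyl group of compound 1

The compounds below may be only part of what the source reports. "The series", "measured", "known", "first", "only" and "open" are said of these compounds alone.

Measured in a functional assay on NCI-H460 cells (Homo sapiens) for cytotoxicity, read by sulforhodamine B assay, with a stated time of 3 days (a lower number here means a stronger inhibitor, a higher number a weaker inhibitor), so far:
Compound 1 (`OCc1cn(Cc2ccc(Cl)cc2)c2ccccc12`) value 16 nM
Compound 2 (`COc1ccc(Cn2cc(CO)c3ccccc32)cc1`) value 79 nM

Of these two, compound 1 has the lower number and so is the stronger inhibitor. Going by the values given here, the only measured step, with methoxy in place of chloro on an aromatic carbon, is a 4.9-fold higher number from compound 1 to compound 2 (0.69 log units; beyond the scatter) in size.

Compound 3 (`COCc1cn(Cc2ccc(Cl)cc2)c2ccccc12`) keeps the chloro group and differs elsewhere: methyl in place of hydrogen on an oxygen on a saturated carbon with methyl in place of hydrogen on an oxygen on a saturated carbon, so hydroxymethyl becomes methoxymethyl. Among the compounds with values here, no measured step touches this group. The step above shows only how far one small change has moved the number in this series. A modest rise in this assay is expected, since compound 1 at 16 nM is the lower of the two values. The estimate for compound 3 is 60 nM within an expected range of 15 nM to 250 nM as a likely result. This estimate means a 3.8-fold higher number from compound 1 to compound 3 (0.57 log units; beyond the scatter) as the expected step.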

Compound 3, half-maximal inhibitory concentration: 1990 nM
Beside the measured number, compound 3's estimate is 33-fold (1.52 log units) below it; measured number above the stated range.
By their numbers in this assay, from the lowest: compound 1; then compound 2; then compound 3.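

In this assay the methyl added to the oxygen gives a 120-fold higher number from compound 1 to compound 3 (2.09 log units; beyond the scatter) and shows that this position responds strongly to even a very small change. The earlier change of chloro to methoxy gives a 4.9-fold higher number from compound 1 to compound 2 (0.69 log units; beyond the scatter) and is the smaller of the two steps, so among these compounds the hydroxymethyl group is the more sensitive place; keeping the oxygen does not by itself keep the number low. Nothing available explains why the methyl has so large an effect here.

On these data alone, it remains open whether an amine, a carboxylic acid or a longer chain in place of the hydroxymethyl group would keep the number low or raise it. As far as these compounds go, it is also open whether methylating the oxygen would have as large an effect with methoxy in place of chloro.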